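Replacing an Ester Tail with a Free Acid

This account rests on a few compounds, and the source may have more. Where it says the series, first, only, none or still open, it means among the compounds named here.

Measured compounds:
- compound 1 `CC(C)OCCOC(=O)c1cccc(-c2cc(C(=O)Nc3ccncc3F)ccc2CN)c1` — 37 nM
- compound 2 `CC(N)c1ccc(C(=O)Nc2ccncc2)cc1-c1ccc(F)cc1` — 1.2 nM
- compound 3 `NCc1ccc(C(=O)Nc2ccncc2)cc1-c1cccc(C(=O)OCC2CCCC2)c1` — 5 nM

In an assay on isolated protein for inhibition of Rho-associated protein kinase 2 (Homo sapiens), read by radiometric assay (on this read-out lower numbers stand for stronger inhibition and higher numbers for weaker inhibition), compound 1 gives 37 nM, the highest of the three numbers shown. The nearest neighbour is compound 3, which gives 5 nM, a gap beyond the usual scatter. Compound 2 lies furthest away with 1.2 nM, also well beyond the scatter.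

The untested compound 4 `NCc1ccc(C(=O)Nc2ccncc2F)cc1-c1cccc(C(=O)O)c1` is compound 1 with one change: hydrogen in place of 2-isopropoxyethyl on an oxygen next to a carbonyl group. Cut one bond further out, the (2-isopropoxyethoxy)carbonyl group becomes a carboxy group. Among the compounds with values here, no pair of measured compounds differs by exactly this change, so there is no directly comparable step to lean on; compound 3 differs from compound 1 in more than one place and cannot be used to read off this single change.

The step from compound 1 to compound 4 is therefore expected to be modest, estimated as a 1.6-fold higher number from compound 1 to compound 4 (0.21 log units; within the scatter), with a slight lean towards a higher number. For compound 4 the estimated value in this assay is 60 nM, within a range from 15 nM to 250 nM.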

Compound 4, half-maximal inhibitory concentration: 55 nM
The estimate for compound 4 lay 1.1-fold (0.04 log units) above the measured number, within the range that was stated.
By their numbers in this assay, from the lowest: compound 2; then compound 3; then compounds 1 and 4 (each within the scatter of the next).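

At this place, on an oxygen next to a carbonyl group, this assay shows a 1.5-fold higher number from compound 1 to compound 4 (0.17 log units; within the scatter), so the two compounds cannot be told apart even though the whole 2-isopropoxyethyl group gives way to a single hydrogen. Within the data shown here, this is the first comparison here that isolates one change, since the earlier compounds differ from one another in more than one place and could not show what this exchange does alone. Nothing measured here offers a reason for this result.

One pair on one core cannot show whether the same exchange would give a similar result on another core, such as that of compound 3. It also leaves open how a small methyl ester, a primary amide or a longer chain on this oxygen would compare.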